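The source may report more compounds than this note shows. Statements on the series, on what has been measured and on what is new or still open speak of the compounds shown alone.

In a functional assay on SW1573 cells (Homo sapiens) for antiproliferative activity, read by sulforhodamine B assay, with a stated time of 48 h (on this read-out lower numbers stand for stronger inhibition of growth and higher numbers for weaker inhibition of growth), compound 1 `CC(C)(C)[Si](C)(C)O[C@@H]1CCCO[C@@H]1COCC(=O)O` reads > 100000 nM, which is a limit of the assay and not a number. Compound 2 `C=CCOC[C@H]1OCCC[C@H]1O[Si](C)(C)C(C)(C)C` gives 18000 nM. For the measured compounds named here, the only measured step, an at least 5.5-fold lower number from compound 1 to compound 2 (0.74 log units; beyond the scatter), puts vinyl in place of carboxy and goes beyond the scatter. Going by the values given here, compound 3 `CC(C)(C)[Si](C)(C)O[C@@H]1CCCO[C@@H]1CO/C=C/C(=O)OCc1ccccc1` gives 26000 nM, the higher of the two actual numbers, although this value lies within the scatter of the one for compound 2.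

The next structure is compound 4 `COC(=O)/C=C/OC[C@H]1OCCC[C@H]1O[Si](C)(C)C(C)(C)C`, and the change is hydrogen in place of phenyl on a saturated chain carbon bound to an oxygen next to a carbonyl group. In short, benzyloxy gives way to methoxy. Among the compounds with values here, no measured step covers this exchange. The step to compound 2 at 18000 nM concerns a different group, so it offers only a loose guide and sets no size for the change expected here. With nothing measured to suggest a shift, the estimated step is a 1.2-fold higher number from compound 3 to compound 4 (0.06 log units; within the scatter), which is expected to stay within the scatter in this assay, with no firm direction.

For compound 4, the estimated value is 30000 nM, with an expected range from 12000 nM to 75000 nM.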

Compound 4, concentration for 50% growth inhibition: 50000 nM
Beside the measured number, compound 4's estimate is 1.7-fold (0.22 log units) below it; measured number inside the range.
By their numbers in this assay, from the lowest: compounds 2, 3 and 4 (each within the scatter of the next, the first and the last beyond it). At a limit, above all of these: compound 1.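

In this assay, for the compounds shown here, the benzyloxy-to-methoxy exchange on the ester gives the first reading for this change: a 1.9-fold higher number from compound 3 to compound 4 (0.28 log units; within the scatter). Removing the phenyl at this place therefore produces no shift that can be told from the scatter, so these two compounds show no clear role for the aromatic ring in this read-out. A change at the oxygen on the saturated carbon does register, as 2-(methoxycarbonyl)ethenyl in place of allyl gives a 2.8-fold higher number from compound 2 to compound 4 (0.44 log units; beyond the scatter), while the comparison with the carboxymethyl compound, an at least 2.0-fold lower number from compound 1 to compound 4 (0.30 log units; that floor lies within the scatter), rests on a limit and not a number and fixes only a floor: the limit of > 100000 nM in this assay, at which 1 of the 4 values shown sits.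

As far as these compounds go, it remains open whether an ethyl or longer alkyl ester, an amide or a free carboxylic acid on the ethenyl chain would separate from the methyl and benzyl esters in this assay. The compounds shown also leave open how a free hydroxyl in place of the silyl ether would read on the shared core, since all of them carry that silyl ether.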